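The compounds below may be only part of what the source reports. "The series", "measured", "known", "first", "only" and "open" are said of these compounds alone.

Of the compounds shown here, three of one shared core have been measured in an assay on isolated protein for inhibition of sterol O-acyltransferase 1 (Mus musculus), tested at 0.1 uM; a lower number here means less inhibition, a higher number more inhibition at the concentration tested (going by the name of the read-out). Compound 1 `CCCCCCCCCCCCn1nnc(C(C(=O)Nc2ncccc2C)c2ccccc2)n1` gives 4%, and compound 2 `CCCCCCCCCCCCn1nnc(C(C(=O)Nc2c(C)nn(C)c2C)c2ccccc2)n1` gives 66%; the change of 1,3,5-trimethyl-1H-pyrazol-4-yl in place of 3-methylpyridin-2-yl on an amide-type nitrogen brings a number 62 percentage points higher from compound 1 to compound 2 (beyond the scatter). Compound 3 `CCCCCCCCCCCCn1nnc(C(C(=O)Nc2c(OC)cc(OC)cc2OC)c2ccc(N(C)C)cc2)n1` gives 0% in this assay, the lowest of the three numbers: compound 1 lies within the scatter of it, while compound 2 stands far beyond the scatter above it.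

Compound 4 `CCCCCCCCCCCCn1nnc(CC(=O)Nc2c(OC)cc(OC)cc2OC)n1` is not yet measured. It differs from compound 3 in one place: hydrogen in place of 4-(dimethylamino)phenyl on a saturated chain carbon bound to an aromatic carbon and a carbonyl carbon. Among the measured compounds shown here, none of the measured steps touches this saturated chain carbon; the only measured step concerns the amide-type nitrogen, so no step on record bears on this change. Because compound 3 gives 0%, the inhibition of compound 4 is expected to stay low, with a number 4 percentage points higher from compound 3 to compound 4 (within the scatter) as the expected step, which is within the scatter. Compound 4 is therefore estimated at 4%, between 0% and 16%.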

Compound 4, a percentage reported as inhibition, at one concentration (the size of the read-out at that concentration, not a potency): 66%
Compound 4: the middle estimate sits 62 percentage points below what was measured; measured number above the stated range.
By their numbers in this assay, from the lowest: compounds 3 and 1 (each within the scatter of the next); then compounds 2 and 4 (each within the scatter of the next).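

In this assay, hydrogen in place of 4-(dimethylamino)phenyl on the saturated chain carbon gives a number 66 percentage points higher from compound 3 to compound 4 (beyond the scatter), so this position, which the earlier step on the amide-type nitrogen did not touch, can carry a large change on its own. The group on the amide-type nitrogen is the same in both compounds, so the low number of compound 3 cannot be read as belonging to that group alone. Nothing at hand explains why this exchange has so large an effect.

Open, on these data alone, is whether the ring or its dimethylamino group accounts for the step, which a plain phenyl at this carbon, paired with the amide group of compound 4, would separate. Also open, as far as these compounds go, is how a small group such as methyl, or an amine or a carboxylic acid, would fare at this carbon.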